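Adding a Second Chloro to the Fused Ring

The source may hold more compounds than are shown below. What is called first, only, known or untested is meant among the compounds shown, and "the series" means these compounds.

Compound 1 `O=c1[nH]c(Nc2cc(Cl)cc(Cl)c2)nc2cc(Cl)ccc12` was tested in an ADME assay on Vero cells (Chlorocebus sabaeus) for cytotoxicity, read by WST assay; on this read-out lower numbers stand for higher toxicity in this test and higher numbers for lower toxicity in this test. In this assay compound 1 gives only a limit, > 25000 nM. Compound 1 therefore sits at the limit of > 25000 nM in this assay, at which 1 of the 2 values shown sits. Compound 2 `O=c1[nH]c(Nc2cc(Cl)cc(Cl)c2)nc2cc(C(F)(F)F)ccc12` gives 7100 nM in this assay, and the step of an at least 3.5-fold lower number from compound 1 to compound 2 (0.54 log units; beyond the scatter) is the only measured one. Compound 3 `O=c1[nH]c(Nc2cc(Cl)cc(Cl)c2)nc2c(Cl)c(Cl)ccc12` differs from compound 1 by chloro in place of hydrogen on an aromatic carbon. Going by the values given here, no measured step matches this change, and the step from compound 1 to compound 2 concerns a different group, so little about the size can be inferred. Compound 3 is expected to give about 20000 nM in this assay, between 6000 nM and 60000 nM, which means an expected step of an at least 1.2-fold lower number from compound 1 to compound 3 (0.09 log units; that floor lies within the scatter).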

Compound 3, half-maximal cytotoxic concentration: > 25000 nM
Compound 3 was reported as a limit; the forecaster's own chance of this, stated with the estimate: 45%; middle value at least 1.2-fold (0.09 log units) away from the limit.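

Compound 1 and compound 3 both stand only as limits in this assay, and no step can be read between them: the limit of > 25000 nM in this assay, at which 2 of the 3 values shown sit.

From the compounds shown here alone, whether chloro in place of hydrogen on this aromatic carbon shifts the half-maximal cytotoxic concentration at all stays open.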